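This account rests on a few compounds, and the source may have more. Where it says the series, first, only, none or still open, it means among the compounds named here.

Series notes, agonist response.

Measured in a functional assay on HEK293T cells for agonist activity at histamine H2 receptor (Homo sapiens), read by beta-arrestin recruitment; a lower number here means a smaller maximal response, a higher number a larger maximal response:
- compound 1, `Cc1nc(N)sc1CCCN/C(N)=N/C(=O)N[C@H](C)c1ccccc1`, gives 0.34
- compound 2, `CCCNC(=O)/N=C(\N)NCCCc1sc(N)nc1C`, gives 0.32
- compound 3, `Cc1nc(N)sc1CCCN/C(N)=N/C(=O)N[C@@H](C)c1ccccc1`, gives 0.46

Compound 3 stands highest of the three in this assay. Against compound 1 the difference is a number 0.12 higher from compound 1 to compound 3 (beyond the scatter), and the only thing separating these two is the fact that compounds 1 and 3 differ only in the configuration as drawn. Against compound 2 the difference is a number 0.14 higher from compound 2 to compound 3 (beyond the scatter). Between compound 1 and compound 2 the step is a number 0.020 lower from compound 1 to compound 2 (within the scatter), so the propyl compound and the R-configured 1-phenylethyl compound are not separated here.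

Compound 4, `CCCCCCNC(=O)/N=C(\N)NCCCc1sc(N)nc1C`, is not yet measured. It differs from compound 3 as follows: hexyl in place of 1-phenylethyl on an amide-type nitrogen. Within the data shown here, the step that bears on this is the one from compound 2 to compound 3, where putting 1-phenylethyl in place of propyl on the amide-type nitrogen raised the response by a number 0.14 higher from compound 2 to compound 3 (beyond the scatter). Among the measured compounds shown here, compound 4 goes the other way, back to a plain alkyl chain on that nitrogen, hexyl rather than propyl, and there is no measured step for lengthening the alkyl. The expectation is therefore a drop of about the size seen between compound 2 and compound 3, landing near the propyl compound, as a step a number 0.12 lower from compound 3 to compound 4 (beyond the scatter).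

Compound 4 is estimated at 0.34 in this assay, expected to fall between 0.22 and 0.46.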

Compound 4, intrinsic activity: the largest response reached, as a fraction of the reference agonist's: 0.28
For compound 4 the middle estimate is 0.060 above the measured one; measured number inside the range.
By their numbers in this assay, from the lowest: compounds 4, 2 and 1 (each within the scatter of the next); then compound 3.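

In this assay the swap of 1-phenylethyl for hexyl on the amide-type nitrogen reads differently depending on the configuration of the group that leaves: it costs response when the S-drawn group leaves (a number 0.18 lower from compound 3 to compound 4 (beyond the scatter)), but the same swap from the R-drawn group does not separate the pair (a number 0.060 lower from compound 1 to compound 4 (within the scatter)). On the plain alkyl side, hexyl and propyl are not separated either (a number 0.040 lower from compound 2 to compound 4 (within the scatter)), so over these two chains the added carbons show no effect on the maximal response, and hexyl gives no gain to set against the S-drawn 1-phenylethyl group. Compounds 1, 2 and 4 therefore sit together and compound 3 alone stands apart, which ties the raised response to the S-drawn arrangement rather than to the presence of a phenyl ring as such, with compound 1 as the case against a ring alone sufficing: the fact that compounds 1 and 3 differ only in the configuration as drawn.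

Open, from the compounds shown here alone, is whether a benzyl group, without the branching methyl, would keep any of the response seen with compound 3. Also open, going by these compounds, is whether a chain longer than hexyl, or one ending in an amine or a carboxylic acid, would move the response away from the level of the plain alkyl compounds.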